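Replacing a ring bromine with hydroxymethyl on the pyridyloxy ether

The source may report more compounds than this note shows. Statements on the series, on what has been measured and on what is new or still open speak of the compounds shown alone.

Of the compounds shown here, three sharing one core have been measured in an assay on membranes from brain for displacement of a labelled ligand from Neuronal acetylcholine receptor; alpha4/beta2 (Rattus norvegicus); on this read-out higher numbers stand for weaker inhibition and lower numbers for stronger inhibition. The parent, compound 1 `CN1CCC[C@H]1COc1cccnc1`, gives 0.15 nM in this assay. Compound 2 `Cc1ccc(OC[C@@H]2CCCN2C)cn1` carries a methyl on the ring and gives 1.26 nM. Compound 3 `CN1CCC[C@H]1COc1ccc(Br)nc1`, with a bromine at the same place, gives 1.91 nM, the highest of the three numbers; its nearest neighbour is compound 2, with a gap within the scatter, while compound 1 lies furthest away.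

The next step leads to compound 4 `CN1CCC[C@H]1COc1ccc(CO)nc1`, differing from compound 3 by hydroxymethyl in place of bromo on an aromatic carbon. For the measured compounds named here, two measured steps bear on this. Placing a group at this ring carbon cost an 8.4-fold higher number from compound 1 to compound 2 (0.92 log units; beyond the scatter) and a 13-fold higher number from compound 1 to compound 3 (1.10 log units; beyond the scatter), whereas the exchange of one such group for another gave a 1.5-fold higher number from compound 2 to compound 3 (0.18 log units; within the scatter). A substituent at this position thus appears to matter more than which substituent it is, on the evidence of only two substituents.

For compound 4 the expected outcome is therefore a step of a 1.6-fold higher number from compound 3 to compound 4 (0.20 log units; within the scatter) in this assay, a small shift upward that may well stay within the scatter. Compound 4 is estimated at 3 nM, with a likely range from 0.8 nM to 12 nM.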

Compound 4, inhibition constant: 97.4 nM
The estimate for compound 4 lay 32-fold (1.51 log units) below the measured number, outside the stated range (above it).
By their numbers in this assay, from the lowest: compound 1; then compounds 2 and 3 (each within the scatter of the next); then compound 4.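

In this assay the earlier picture, in which having a substituent at this ring carbon mattered more than which one it was, holds only for methyl and bromo; compound 4 goes against it, since hydroxymethyl in place of bromo gives a 51-fold higher number from compound 3 to compound 4 (1.71 log units; beyond the scatter) and the single added hydroxy on the methyl group gives a 77-fold higher number from compound 2 to compound 4 (1.89 log units; beyond the scatter) while the methyl-to-bromo exchange stayed within the scatter. Measured from the unsubstituted parent, hydroxymethyl in place of hydrogen amounts to a 650-fold higher number from compound 1 to compound 4 (2.81 log units; beyond the scatter) and so costs far more than either earlier substituent, which shows that the identity of the group at this carbon, next to the ring nitrogen, can dominate the read-out. Nothing available explains why this one change has so large an effect.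

The compounds shown leave open whether the loss follows the free hydroxy itself, which a methoxymethyl group would test, or extends to other groups at this carbon such as an aminomethyl group, a carboxylic acid or a longer hydroxyalkyl chain. They also leave open whether hydroxymethyl would carry the same cost at any other ring carbon.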